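Trimming ethylsulfanyl to methylsulfanyl on a shared core

A few compounds are considered here, and "the series" means these few. Any claim that something is new, unique, unknown or untested is made for them only; others in the source may bear on it.

In a functional assay for inhibition, tested at 100 uM (on this read-out lower numbers stand for less inhibition and higher numbers for more inhibition at the one concentration tested (going by the name of the read-out)), compound 2 `CCSC1=N[C@H](C(=O)OC)[C@@H]2C(=O)N(c3ccccc3)C(=O)[C@H]12` gives 89%, the second highest of three numbers. Compound 1 `CCSC1=N[C@@H](C(=O)OC)[C@@H]2C(=O)N(c3ccccc3)C(=O)[C@H]12` gives 91% and compound 3 `CCCSC1=N[C@@H](C(=O)OC)[C@@H]2C(=O)N(c3ccccc3)C(=O)[C@H]12` gives 86%. The step of a number 2 percentage points lower from compound 1 to compound 2 (within the scatter) rests only on a change of configuration the fact that compounds 1 and 2 differ only in the configuration as drawn and lies within the scatter. The step of a number 5 percentage points lower from compound 1 to compound 3 (within the scatter), which added a methyl to the sulfur-bound chain, also lies within the scatter. Compound 4 `COC(=O)[C@H]1N=C(SC)[C@H]2C(=O)N(c3ccccc3)C(=O)[C@H]21` is compound 2 with hydrogen in place of methyl on a saturated chain carbon bound to a sulfur. For the measured compounds named here, this alters the same chain, and the only comparable measured change, a number 5 percentage points lower from compound 1 to compound 3 (within the scatter), left this assay unmoved beyond the scatter, so no step beyond the scatter is expected here either. Compound 4 is therefore expected to give 88%, between 78% and 95%. The expected step of a number 1 percentage points lower from compound 2 to compound 4 (within the scatter) stays within the scatter.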

Compound 4, a percentage reported as inhibition, at one concentration (the size of the read-out at that concentration, not a potency): 84%
Compound 4: the middle estimate sits 4 percentage points above what was measured; the range from low to high includes it.
By their numbers in this assay, from the lowest: compounds 4, 3, 2 and 1 (each within the scatter of the next).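

In this assay, trimming ethylsulfanyl to methylsulfanyl gives a number 5 percentage points lower from compound 2 to compound 4 (within the scatter). The chain on the sulfur has now been both shortened and lengthened without a step beyond the scatter, and the methyl change reads alike on the two cores as far as the scatter allows: the same change on two cores in this assay, a number 5 percentage points lower (within the scatter) from compound 1 to compound 3 and a number 5 percentage points higher (within the scatter) from compound 4 to compound 2, 10 percentage points apart, within the scatter of two such steps

The compounds shown leave open whether an amine, a carboxylic acid or a much longer chain at this place would move this assay beyond the scatter. A reading at one concentration also gives no potency for any of them.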